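This account rests on a few compounds, and the source may have more. Where it says the series, first, only, none or still open, it means among the compounds named here.

Measured compounds:
- compound 1, `COc1ccc(CN(C)C(C)CCn2c(=O)oc3ccccc32)cc1`: 21 nM
- compound 2, `COc1ccc(CN(C)CCCn2c(=O)oc3ccccc32)cc1`: 83 nM
- compound 3, `O=C(NCc1ccccc1)C1CCN(Cc2ccccc2)CC1`: 22.5 nM

All three were tested in an assay on membranes from liver for displacement of a labelled ligand from Sigma non-opioid intracellular receptor 1 (Rattus norvegicus), read by scintillation counting; on this read-out lower numbers stand for stronger inhibition and higher numbers for weaker inhibition. On these numbers compound 2 stands highest, that is, it is the weakest of the three; its nearest neighbour is compound 3, and compound 1 lies furthest from it. For the measured compounds named here, the one step that links two measured compounds runs a 4.0-fold higher number from compound 1 to compound 2 (0.60 log units; beyond the scatter), where a methyl on the saturated chain is replaced by hydrogen, so that change alone moved the number by a modest amount.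

Compound 4, `CN(CCCn1c(=O)oc2ccccc21)Cc1ccccc1`, has not been measured. It differs from compound 2 by hydrogen in place of methoxy on an aromatic carbon; cut one bond further out, the same difference reads 4-methoxyphenyl to phenyl. Going by the values given here, no measured step touches this change: the only step in hand concerns the chain, not the aromatic ring. Compound 3, which carries a plain benzyl group, shows a lower number than compound 2, but the two compounds differ in more than one place, so that comparison shows only what its two values show. With nothing direct to lean on, the step from compound 2 to compound 4 is expected to stay within the scatter, a 1.0-fold lower number from compound 2 to compound 4 (0.02 log units; within the scatter). Compound 4 is therefore estimated at 80 nM, with a range from 30 nM to 250 nM.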

Compound 4, inhibition constant: 223 nM
Compound 4: the middle estimate sits 2.8-fold (0.45 log units) below what was measured; the range from low to high includes it.
By their numbers in this assay, from the lowest: compounds 1 and 3 (each within the scatter of the next); then compound 2; then compound 4.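

Taking the methoxy off the aromatic ring is not a neutral change in this assay: the step runs a 2.7-fold higher number from compound 2 to compound 4 (0.43 log units; beyond the scatter), so on this shared core the 4-methoxyphenyl group gives stronger inhibition than plain phenyl, and a group at this place on the ring can shift the number beyond the usual scatter. The earlier step concerned only the saturated chain, running a 4.0-fold higher number from compound 1 to compound 2 (0.60 log units; beyond the scatter), so in both listed steps the loss of a small group, first methyl and now methoxy, raises the number by a modest amount. Nothing available here explains why removing the methoxy weakens inhibition.

A single replacement cannot show whether methoxy itself matters or whether another group in its place, such as ethoxy, hydroxy or chlorine, would serve as well. As far as these compounds go, it also remains open how the two changes combine, which a compound with the chain methyl of compound 1 and the plain phenyl of compound 4 could show.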